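From Iodine to Fluorine: An Outlook for Compound 4

This account rests on a few compounds, and the source may have more. Where it says the series, first, only, none or still open, it means among the compounds named here.

Three compounds have been measured in an ADME assay on MT4 cells (Homo sapiens) for cytotoxicity; on this read-out higher numbers stand for lower toxicity in this test and lower numbers for higher toxicity in this test:
- Compound 1 `FC(F)(F)c1cccc(NC(=S)Nc2ccc(I)cc2)c1`: 10000 nM
- Compound 2 `CCCCc1ccc(NC(=S)Nc2cccc(C(F)(F)F)c2)c(C)c1`: 43000 nM
- Compound 3 `O=C(NC(=S)Nc1cccc(C(F)(F)F)c1)[C@H]1C[C@@H]2CC[C@H]1C2`: 42000 nM

Compound 1 stands lowest of the three in this assay, and its gaps to compound 3 and to compound 2 both lie beyond the usual scatter, so it is the most toxic of the measured set here. Compound 4 `Fc1ccccc1NC(=S)Nc1cccc(C(F)(F)F)c1` has not yet been measured; it differs from compound 1 in one place: 2-fluorophenyl in place of 4-iodophenyl on an amide-type nitrogen. Within the data shown here, no measured pair shows this exact change, so the account rests on the two higher values of compound 2 and compound 3. Compound 4 is expected to move upward, an estimated step of a 2.5-fold higher number from compound 1 to compound 4 (0.40 log units; beyond the scatter), and to give about 25000 nM, within a range from 8000 nM to 80000 nM.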

Compound 4, half-maximal cytotoxic concentration: 47000 nM
Beside the measured number, compound 4's estimate is 1.9-fold (0.27 log units) below it; low and high end bracket the measured number.
By their numbers in this assay, from the lowest: compound 1; then compounds 3, 2 and 4 (each within the scatter of the next).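

In this assay, among these compounds, 2-fluorophenyl in place of 4-iodophenyl on the amide-type nitrogen gives a 4.7-fold higher number from compound 1 to compound 4 (0.67 log units; beyond the scatter), the first direct pair at this position. It shows that the aryl group on this nitrogen can alone shift the read-out beyond the scatter, here toward lower toxicity in this test.

As far as these compounds go, the change swaps both the halogen and its place on the ring, so which of the two carries the step remains open, as does the outcome with an amine or a carboxylic acid there. No measurement at hand accounts for the step.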